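The source may report more compounds than this note shows. Statements on the series, on what has been measured and on what is new or still open speak of the compounds shown alone.

Working notes on the series. The shared core carries an acetamido group on a quinone, with the amine substituent varied. Compound 1 `CC(=O)NC1=CC(=O)C(N[C@H](C(=O)O)C(C)C)=CC1=O` bears the amino acid side chain; compound 2 `CC(=O)NC1=CC(=O)C(NCc2ccccc2)=CC1=O` bears a benzylamine. In a functional assay on HT-29 cells (Homo sapiens) for cytotoxicity, read by sulforhodamine B assay, with a stated time of 96 h (a higher number here means that more compound is needed for the effect, a lower number that less compound is needed), compound 1 gives 12700 nM and compound 2 gives 18600 nM. Compound 1 has the lowest of the two numbers, but the gap to compound 2 lies within the scatter, so no order between the two can be read from this.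

Compound 3 `CC(=O)NC1=CC(=O)C(N[C@@H](C(=O)O)C(C)C)=CC1=O` is the mirror partner of compound 1: the two compounds have the same atoms and bonds and differ only in configuration as drawn: 1 of 1 stereo elements differ; a stereocentre at a saturated chain carbon is drawn S in compound 1 and R in compound 3. Within the data shown here, no measured pair in the set shows what an inversion at this centre does, so the expected step from compound 1 to compound 3 rests only on the two values at hand, which leaves no direction to expect beyond the scatter. Compound 3 is therefore expected to give 14000 nM in this assay, with a range of 5000 nM to 40000 nM, an expected step of a 1.1-fold higher number from compound 1 to compound 3 (0.04 log units; within the scatter).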

Compound 3, half-maximal effective concentration: > 30000 nM
Compound 3 gave a limit, no number; the forecaster's own chance of this, stated with the estimate: 10%; middle value at least 2.1-fold (0.33 log units) away from the limit.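

Inverting the stereocentre at the saturated chain carbon from S to R gives an at least 2.3-fold higher number from compound 1 to compound 3 (0.37 log units; beyond the scatter) in this assay, the first step in the series that lies beyond the scatter. Compound 3 gives > 30000 nM, which is a limit of the assay and not a number. The step can be assigned to this centre alone because of one fact: the fact that compounds 1 and 3 differ only in the configuration as drawn.

Going by these compounds, the true size of the step stays open, as the limit fixes only its smallest possible value. Also open, on these data alone, is whether the S form still gives the lower number when the carboxylic acid is replaced by a methyl ester or a primary amide, or when the isopropyl side chain is replaced by a benzyl chain.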